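The compounds below may be only part of what the source reports. "The series", "measured", "known", "first", "only" and "open" are said of these compounds alone.

Compound 1: `C[C@H](Nc1ccc(S(=O)(=O)Nc2nccs2)cc1Cl)c1ccccc1` gives 130 nM in an assay on HEK293 cells for inhibition of SCN8A/SCN1B (Homo sapiens), read by patch clamp, with a stated time of 20 min; on this read-out higher numbers stand for weaker inhibition and lower numbers for stronger inhibition.
Compound 2: `C[C@H](Nc1cc(F)c(S(=O)(=O)Nc2nccs2)cc1Cl)c1ccccc1` gives 20 nM in this assay.
Compound 3: `C[C@H](Nc1cc(F)c(S(=O)(=O)Nc2cscn2)cc1Cl)c1ccccc1F` gives 410 nM in this assay.

Compound 1 and compound 2 differ by fluoro in place of hydrogen on an aromatic carbon, a change that brought a 6.5-fold lower number from compound 1 to compound 2 (0.81 log units; beyond the scatter). Compound 3 carries a different core; how it differs from the core of compound 1 is not broken down here, but its number stands highest of the three.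

Compound 4, `C[C@H](Nc1cc(F)c(S(=O)(=O)Nc2cscn2)cc1Cl)c1cc(F)ccc1F`, is not yet measured. It differs from compound 3 by fluoro in place of hydrogen on an aromatic carbon, the same kind of change as that from compound 1 to compound 2, though not the same: there the entering fluoro sat ortho to a group of 9 heavy atoms, meta to a group of 9 heavy atoms and para to a chloro group, while here it sits meta to a large group and para to a fluoro group. Since the surroundings differ, the earlier step is a weak guide, and a smaller step is expected, about a 1.4-fold lower number from compound 3 to compound 4 (0.14 log units; within the scatter). Compound 4 is therefore estimated at 300 nM, between 100 nM and 900 nM.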

Compound 4, half-maximal inhibitory concentration: 119 nM
The estimate for compound 4 lay 2.5-fold (0.40 log units) above the measured number; low and high end bracket the measured number.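

Replacing hydrogen with fluoro on the 2-fluorophenyl group gave a 3.4-fold lower number from compound 3 to compound 4 (0.54 log units; beyond the scatter) in this assay. Both steps lowered the number, and their sizes cannot be told apart: the same change on two cores in this assay, a 6.5-fold lower number (0.81 log units; beyond the scatter) from compound 1 to compound 2 and a 3.4-fold lower number (0.54 log units; beyond the scatter) from compound 3 to compound 4, 1.9-fold (0.28 log units) apart, within the scatter of two such steps. This shows that the change carried over to a second core in direction and rough size, but the fluoro entered at a different place in each pair, so two pairs give no general rule and do not show what lies behind the steps.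

The compounds shown leave open whether a methyl, methoxy or nitrile group in place of the entering fluoro would also lower the number. They also leave open how the 2,5-difluorophenyl group would behave on the core of compound 2.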